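Trimethylphenyl replacing methoxyphenyl on the shared core

The compounds below may be only part of what the source reports. "The series", "measured", "known", "first", "only" and "open" are said of these compounds alone.

Measured compounds:
compound 1 `CCCc1ccc(-c2cc(=O)c3c(o2)C(CC)(CC)C(=O)C(CC)=C3O)cc1` — 12.2 uM
compound 2 `CCC1=C(O)c2c(oc(-c3ccc(OC)cc3)cc2=O)C(CC)(CC)C1=O` — 0.68 uM
compound 3 `CCC1=C(O)c2c(oc(-c3cccc(OC)c3)cc2=O)C(CC)(CC)C1=O` — 1.22 uM

In a functional assay on KBVIN cells (Homo sapiens) for antiproliferative activity, read by sulforhodamine B assay, with a stated time of 3 days (on this read-out lower numbers stand for an effect already at smaller amounts and higher numbers for an effect only at larger amounts of compound), compound 3 gives 1.22 uM, the second highest of the three numbers; the nearest step is a 1.8-fold higher number from compound 2 to compound 3 (0.25 log units; within the scatter), and compound 1 stands further off, a 10-fold lower number from compound 1 to compound 3 (1.00 log units; beyond the scatter).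

Compound 4 `CCC1=C(O)c2c(oc(-c3cc(C)c(C)cc3C)cc2=O)C(CC)(CC)C1=O` is not yet measured. The change from compound 3 is 2,4,5-trimethylphenyl in place of 3-methoxyphenyl on an aromatic carbon. For the measured compounds named here, the steps that bear on it run the other way: an 18-fold lower number from compound 1 to compound 2 (1.25 log units; beyond the scatter) and a 10-fold lower number from compound 1 to compound 3 (1.00 log units; beyond the scatter), both from an alkyl-bearing phenyl to a methoxy-bearing one. Going back from a methoxy group to methyl groups only, a higher number is expected for compound 4, a step of a 4.1-fold higher number from compound 3 to compound 4 (0.61 log units; beyond the scatter) in this assay, smaller than the full return to compound 1 given the uncertainty of added methyl groups. Compound 4 is estimated at 5 uM, within 1.5 uM to 18 uM.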

Compound 4, concentration for half-maximal effect: 4.37 uM
Compound 4: the middle estimate sits 1.1-fold (0.06 log units) above what was measured; measured number inside the range.
By their numbers in this assay, from the lowest: compounds 2 and 3 (each within the scatter of the next); then compound 4; then compound 1.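

In this assay the 2,4,5-trimethylphenyl group gives a 3.6-fold higher number from compound 3 to compound 4 (0.55 log units; beyond the scatter) and a 6.4-fold higher number from compound 2 to compound 4 (0.81 log units; beyond the scatter) but also a 2.8-fold lower number from compound 1 to compound 4 (0.45 log units; beyond the scatter) on the shared core. At this position, next to the ring oxygen, an aryl group without methoxy therefore need not carry a number as high as that of compound 1. No measurement at hand accounts for these steps.

As far as these compounds go, whether the number, the places or the mere presence of the methyl groups set the value of compound 4 stays open. So does the outcome with an amine, a carboxylic acid or a longer alkoxy chain on this phenyl ring.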